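A Methyl Added to the Phenyl of Compound 2

The compounds below may be only part of what the source reports. "The series", "measured", "known", "first", "only" and "open" are said of these compounds alone.

Compound 1 `CC(C)(C)Nc1nc2cc(-c3ccc(F)cc3)sc2c(=O)[nH]1`: 5100 nM
Compound 2 `CC(C)(C)Nc1nc2cc(-c3ccccc3)sc2c(=O)[nH]1`: 12500 nM

Of these two compounds tested in an ADME assay on HepG2 cells (Homo sapiens) for cytotoxicity, read by MTT assay, with a stated time of 72 h (a higher number here means that more compound is tolerated, a lower number that less compound is tolerated), compound 2 has the higher number. Compound 3 `Cc1ccccc1-c1cc2nc(NC(C)(C)C)[nH]c(=O)c2s1` differs from it in one place: methyl in place of hydrogen on an aromatic carbon (methyl in place of hydrogen on an aromatic carbon, ortho to a large group). For the measured compounds named here, the only measured guide is the modest step of a 2.5-fold higher number from compound 1 to compound 2 (0.39 log units; beyond the scatter), where hydrogen replaces fluoro, so it is a loose guide for adding methyl. A small move toward a lower number is expected, estimated as a 1.3-fold lower number from compound 2 to compound 3 (0.10 log units; within the scatter), and it may not exceed the scatter. Compound 3 is expected at 10000 nM, with 4500 nM to 25000 nM as the estimated range.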

Compound 3, half-maximal cytotoxic concentration: 4000 nM
Compound 3: middle estimate off by 2.5-fold (0.40 log units), on the high side; the measured number lies below the stated range.
By their numbers in this assay, from the lowest: compounds 3 and 1 (each within the scatter of the next); then compound 2.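

Adding methyl to the phenyl, ortho to a large group, gives a 3.1-fold lower number from compound 2 to compound 3 (0.49 log units; beyond the scatter) in this assay and shows that this ring responds to a group other than fluoro. The gap between the 2-methylphenyl and the 4-fluorophenyl is a 1.3-fold lower number from compound 1 to compound 3 (0.11 log units; within the scatter) and leaves those two compounds level, so compound 2, with the plain phenyl, stands apart from both. No measured evidence here explains the shift.

Both groups shown go with lower numbers than plain phenyl. Going by these compounds, whether an amine or a carboxylic acid on this phenyl would do the same remains open.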